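This account rests on a few compounds, and the source may have more. Where it says the series, first, only, none or still open, it means among the compounds named here.

Series notes. The shared core of compound 1 `Cc1ccncc1-c1cccc2c1cnn2-c1nccs1` carries a substituent on the ring nitrogen of the fused system; in compound 1 it is a thiazolyl group, and in an ADME assay on liver (Macaca fascicularis) for metabolic stability, using microsomes, with a stated time of 10 min, tested at 0.5 uM (on this read-out lower numbers stand for a less stable compound and higher numbers for a more stable compound), compound 1 gives "not determined" (no result reported), that is, no result reported. Compound 2 `Cc1ccncc1-c1cccc2c1cnn2-c1ccccc1` carries a phenyl group there, and in this assay compound 2 gives 39%. Compound 3 `Cc1ccncc1-c1cccc2c1cnn2-c1ccc(F)cc1` carries a 4-fluorophenyl group, and in this assay compound 3 likewise gives "not determined" (no result reported), no reported number, so compound 3 stands on no value of its own; among the three measured entries only compound 2 supplies a number. Compound 4 `Cc1ccncc1-c1cccc2c1cnn2-c1ccccn1` is the next entry, still to be measured in this assay. It differs from compound 3 in one place: pyridin-2-yl in place of 4-fluorophenyl on an aromatic nitrogen. Among the compounds with values here, no step between measured compounds is available for this change, so its direction in this assay cannot be read from the series; no step beyond the scatter is assumed, and the only anchor is compound 2 at 39%. Compound 4 is therefore expected near 40% in this assay, estimated between 15% and 70%.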

Compound 4, percent of the compound remaining: 19%
Beside the measured number, compound 4's estimate is 21 percentage points above it, and the stated range covers the measured number.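

At this position, on an aromatic nitrogen of the shared core, this assay now gives a first readable change, with a number 20 percentage points lower from compound 2 to compound 4 (beyond the scatter) for pyridin-2-yl in place of phenyl. Within the data shown here, the earlier compounds offered only a single number, so they could not show that the outcome in this read-out depends on the group at this position; the pair now shows this for one exchange only, a ring nitrogen entering in place of a ring carbon. No measurement at hand accounts for the size or direction of this step.

Steps involving compound 1 or compound 3 cannot be read, as neither has a reported number, so the thiazolyl and 4-fluorophenyl groups remain unplaced relative to phenyl. Also open, as far as these compounds go, is how a non-aromatic group at this position, such as a longer alkyl chain or a phenyl ring carrying an amine or a carboxylic acid, would read.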